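Dimethylamino for Bromo at the Cytotoxicity Limit

This account rests on a few compounds, and the source may have more. Where it says the series, first, only, none or still open, it means among the compounds named here.

Of the compounds shown here, three sharing one core have been tested in a functional assay on A549 cells (Homo sapiens) for cytotoxicity, read by MTT assay; on this read-out lower numbers stand for stronger inhibition and higher numbers for weaker inhibition. Compound 1, `CCOC(=O)C12C(=O)OCC=C1COC2c1ccccc1F`, gives > 1000000 nM, which is a limit of the assay rather than a number. Compound 2, `CCOC(=O)C12C(=O)OCC=C1COC2c1ccc(F)cc1`, gives > 1000000 nM, again a limit. Compound 3, `CCOC(=O)C12C(=O)OCC=C1COC2c1ccc(Br)cc1`, gives > 1000000 nM, also a limit. Compound 3 therefore stands at the same limit as the other two (the limit of > 1000000 nM in this assay, at which 3 of the 3 values shown sit), and the steps a step that the two limits leave unreadable from compound 1 to compound 3 and a step that the two limits leave unreadable from compound 2 to compound 3 cannot be read.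

Compound 4, `CCOC(=O)C12C(=O)OCC=C1COC2c1ccc(N(C)C)cc1`, differs from compound 3 in one place: dimethylamino in place of bromo on an aromatic carbon. Among the compounds with values here, no measured step bears on this change directly. The steps a step that the two limits leave unreadable from compound 1 to compound 2 and a step that the two limits leave unreadable from compound 2 to compound 3 exchange one halogen-bearing phenyl for another, and neither gives a readable size, since every value sits at the limit. Nothing measured here gives a direction for the step into compound 4.

The estimate for compound 4 in this assay is 1000000 nM, with an expected range from 300000 nM to 3000000 nM. The step this estimate means, a number no higher from compound 3 to compound 4 (the limit leaves the size open), is expected to fall within the scatter, and compound 4 is expected most likely to be reported again only as a limit.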

Compound 4, half-maximal inhibitory concentration: 89600 nM
Compound 4: the middle estimate sits 11-fold (1.05 log units) above what was measured; measured number below the stated range.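

In this assay, the steps among the halogen-bearing compounds cannot be read, but this position now gives a readable change: dimethylamino in place of bromo gives an at least 11-fold lower number from compound 3 to compound 4 (1.04 log units; beyond the scatter), and dimethylamino in place of fluoro gives an at least 11-fold lower number from compound 2 to compound 4 (1.04 log units; beyond the scatter). The group on this aromatic carbon, para to a large group, can therefore move the read-out beyond the scatter, which the halogen-bearing compounds alone could not show. Both sizes are minimum sizes rather than exact ones, because the starting compounds have only a limit: the limit of > 1000000 nM in this assay, at which 3 of the 4 values shown sit.

Going by these compounds, it remains open whether the nitrogen itself or simply a larger group matters, a question that a primary amine, a methoxy group or an isopropyl group at this place could help to settle. Also open, on these data alone, is how far the number would move with a longer amine chain, such as diethylamino, or with a carboxylic acid.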